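Chloro to Nitro Swap Across Two Related Cores

The source may report more compounds than this note shows. Statements on the series, on what has been measured and on what is new or still open speak of the compounds shown alone.

Compound 1 `COc1ccc(-c2nnc(N3CCN(C(=O)CN4CCN(c5ccc(Cl)cc5)CC4)CC3)nc2-c2ccc(OC)cc2)cc1` is the starting point. In an ADME assay on NIH3T3 cells (Mus musculus) for cytotoxicity, read by MTT assay, with a stated time of 24 h (a higher number here means a weaker inhibitor, a lower number a stronger inhibitor), compound 1 gives > 814000 nM, which is a limit of the assay and not a number. Compound 2 `COc1ccc(-c2nnc(N3CCN(C(=O)CN4CCN(c5ccc([N+](=O)[O-])cc5)CC4)CC3)nc2-c2ccc(OC)cc2)cc1` differs from compound 1 in one place: nitro in place of chloro on an aromatic carbon. In this assay compound 2 gives > 801000 nM, again a limit of the assay. The step that the two limits leave unreadable from compound 1 to compound 2 is left unreadable by the limit of > 814000 nM in this assay, at which 1 of the 3 values shown sits, and (the limit of > 801000 nM in this assay, at which 1 of the 3 values shown sits), so its size is not known.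

Compound 3 `O=C(CN1CCN(c2ccc(Cl)cc2)CC1)N1CCN(c2nnc(-c3ccc(Cl)cc3)c(-c3ccc(Cl)cc3)n2)CC1` is built on a core that is not the same as the core of compound 1; the difference between the two cores is not broken down here. In this assay compound 3 gives > 803000 nM, which is a limit of the assay, as shown by the limit of > 803000 nM in this assay, at which 1 of the 3 values shown sits.

Compound 4 `O=C(CN1CCN(c2ccc([N+](=O)[O-])cc2)CC1)N1CCN(c2nnc(-c3ccc(Cl)cc3)c(-c3ccc(Cl)cc3)n2)CC1` has not yet been measured. It differs from compound 3 in one place: nitro in place of chloro on an aromatic carbon. Among the compounds with values here, this is the same change as the one from compound 1 to compound 2, made at the same kind of place, on the same kind of ring, para to a large group.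

Compound 4 is expected to sit at a limit as well, resting on compound 3 with its > 803000 nM and on the fact that this change gave no readable movement from compound 1 to compound 2. The step that the limit leaves unreadable from compound 3 to compound 4 is therefore estimated to be small. The expected value of compound 4 is 900000 nM, with a range estimated from 500000 nM to 1600000 nM.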

Compound 4, half-maximal inhibitory concentration: > 789000 nM
Compound 4 was reported as a limit (the forecaster's own chance of this, stated with the estimate: 90%); the middle value does not contradict the limit.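

In this assay compound 4 gives > 789000 nM, which is a limit of the assay and not a number. Within the data shown here, compound 3 also sits at a limit, so the step from compound 3 to compound 4 cannot be read and no new step emerges. The compounds shown leave open whether nitro in place of chloro changes the value at all on either core.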